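Chain extension from compound 2 to compound 3

The source may hold more compounds than are shown below. What is called first, only, known or untested is meant among the compounds shown, and "the series" means these compounds.

For the measured compounds named here, only two compounds on the shared core have numbers so far. In a physicochemical assay for solubility, in phosphate buffer, at pH 7.4 (a higher number here means a more soluble compound, a lower number a less soluble compound), compound 1 (`CNC(=O)Nc1cc(Oc2cncc(OC)c2)c([C@H]2CCCOC2)cn1`) gives 303000 nM, and compound 2 (`CNC(=O)Nc1cc(Oc2cncc(C)c2)c(CCO)cn1`) gives 450000 nM. These two values lie within the scatter of each other, so compound 2 stands level with compound 1 on the available numbers.

Compound 3 (`CNC(=O)Nc1cc(Oc2cncc(C)c2)c(CCCCO)cn1`) keeps the core of compound 2 and changes only the side chain: 2-hydroxyethyl in place of hydroxy on a saturated chain carbon, two bonds along the chain from an aromatic carbon. Cut one bond further out, the same difference reads 2-hydroxyethyl to 4-hydroxybutyl. Going by the values given here, the two measured compounds differ in more than one place, so no measured step shows the effect of this change, and the expectation rests on the structural change alone.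

A moderate fall in this assay is expected, though a result within the scatter would not be surprising. The expected size is a 2.0-fold lower number from compound 2 to compound 3 (0.29 log units; within the scatter), which sits close to the edge of the scatter. For compound 3 the estimated value is 230000 nM, with an expected range of 90000 nM to 480000 nM.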

Compound 3, solubility: 500000 nM
Estimate against measurement, compound 3: 2.2-fold (0.34 log units) below; measured number outside the range, above it.
By their numbers in this assay, from the lowest: compounds 1, 2 and 3 (each within the scatter of the next).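

In this assay, the 2-hydroxyethyl to 4-hydroxybutyl difference now has its first single-place reading, a 1.1-fold higher number from compound 2 to compound 3 (0.05 log units; within the scatter), and this places compound 2 and compound 3 level with each other. For the compounds shown here, compound 1 and compound 2 differ in more than one place, so this step is the first direct look at the side chain on its own, with the rest of the structure held constant. At this position, on a saturated chain carbon, two bonds along the chain from an aromatic carbon, the added length leaves the read-out within the scatter, and no independent measurement is available to account for that outcome.

This is a single step on a single core, so it sets no trend with chain length and says nothing yet about whether the same level reading would hold on the core of compound 1. Also open, going by these compounds, are a longer chain than 4-hydroxybutyl and an amine or a carboxylic acid in place of the hydroxy group on that chain, either of which would test how far this position tolerates change in this assay.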